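This account rests on a few compounds, and the source may have more. Where it says the series, first, only, none or still open, it means among the compounds named here.

Measured so far in an ADME assay on L6 cells (Rattus norvegicus) for cytotoxicity; a higher number here means a weaker inhibitor, a lower number a stronger inhibitor
Compound 1 `CN1CCN(CCC(=O)OC2CC3(N(C)C)CC(c4ccccc4)C2C(c2ccccc2)C3)CC1` gives 31100 nM
Compound 2 `CN1CCN(CCCC(=O)OC2CC3(N4CCCCC4)CC(c4ccccc4)C2C(c2ccccc2)C3)CC1` gives 22300 nM
Compound 3 `CN1CCN(CCCC(=O)OC2CC3(N4CCCC4)CC(c4ccccc4)C2C(c2ccccc2)C3)CC1` gives 10200 nM

Compound 3 has the lowest number of the three, with compound 2 the nearest and compound 1 the furthest. Compound 4 `CN1CCN(CCCC(=O)OC2CC3(N(C)C)CC(c4ccccc4)C2C(c2ccccc2)C3)CC1` has not yet been measured. It carries dimethylamino in place of pyrrolidin-1-yl on a saturated ring carbon and is otherwise the same as compound 3.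

For the measured compounds named here, the one measured step that bears directly on this change is a 2.2-fold lower number from compound 2 to compound 3 (0.34 log units; beyond the scatter), a modest step for pyrrolidin-1-yl in place of piperidin-1-yl. Compound 1 also carries dimethylamino, but it differs in the chain as well, and it gives 31100 nM, so it offers only loose support. A modest step towards a higher number is therefore expected, of about the same size as that measured step. The expected change is a 1.8-fold higher number from compound 3 to compound 4 (0.25 log units; within the scatter) on these few values. For compound 4 the estimated value is 18000 nM, with an expected range from 9000 nM to 36000 nM in this assay.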

Compound 4, half-maximal inhibitory concentration: 19900 nM
For compound 4 the middle estimate is 1.1-fold (0.04 log units) below the measured one; low and high end bracket the measured number.
By their numbers in this assay, from the lowest: compounds 3, 4, 2 and 1 (each within the scatter of the next, the first and the last beyond it).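

In this assay, dimethylamino in place of pyrrolidin-1-yl on this saturated ring carbon gives a 2.0-fold higher number from compound 3 to compound 4 (0.29 log units; within the scatter), and dimethylamino in place of piperidin-1-yl gives a 1.1-fold lower number from compound 2 to compound 4 (0.05 log units; within the scatter), so dimethylamino cannot be told apart from either ring amine, even though the two rings themselves are separated by a 2.2-fold lower number from compound 2 to compound 3 (0.34 log units; beyond the scatter). With dimethylamino held in place, (4-methylpiperazin-1-yl)methyl in place of 4-methylpiperazin-1-yl on the chain gives a 1.6-fold lower number from compound 1 to compound 4 (0.19 log units; within the scatter), so this chain change is not resolved either. Nothing available explains any of these steps.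

As far as these compounds go, it remains open how a primary amine or morpholin-4-yl on the same ring carbon would read in this assay. From the compounds shown here alone, it is also open whether a longer chain carrying the 4-methylpiperazin-1-yl group would move the number beyond the scatter.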